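From fluoro to chloro in a small amide series

The source may hold more compounds than are shown below. What is called first, only, known or untested is meant among the compounds shown, and "the series" means these compounds.

Three compounds have been measured in a functional assay on HepG2 cells (Homo sapiens) for inhibition, read by MTT assay, with a stated time of 72 h; on this read-out higher numbers stand for weaker inhibition and lower numbers for stronger inhibition:
Compound 1 `CC(C)c1ccc(NC(=O)C2CCN(C/C=C/c3ccccc3)CC2)cc1`: 12200 nM
Compound 2 `COc1ccccc1NC(=O)C1CCN(C/C=C/c2ccccc2)CC1`: 91200 nM
Compound 3 `O=C(Nc1cccc(F)c1)C1CCN(C/C=C/c2ccccc2)CC1`: 51100 nM

The numbers place compound 3 close to compound 2, with a 1.8-fold lower number from compound 2 to compound 3 (0.25 log units; within the scatter). It lies further from compound 1, with a 4.2-fold higher number from compound 1 to compound 3 (0.62 log units; beyond the scatter).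

Compound 4 `O=C(Nc1cccc(Cl)c1)C1CCN(C/C=C/c2ccccc2)CC1` differs from compound 3 at a single place: chloro in place of fluoro on an aromatic carbon. This is chloro in place of fluoro on an aromatic carbon, meta to a large group.

Among the measured compounds shown here, no measured step makes this exact exchange. The closest evidence comes from steps that replace the whole substituted phenyl on the amide nitrogen. Two are modest, a 7.5-fold higher number from compound 1 to compound 2 (0.87 log units; beyond the scatter) and a 4.2-fold higher number from compound 1 to compound 3 (0.62 log units; beyond the scatter), while a 1.8-fold lower number from compound 2 to compound 3 (0.25 log units; within the scatter) does not leave the scatter. Since the exchange here touches only one substituent, no step beyond the scatter is expected, and the data give only a weak hint of direction. In this assay the expected step is a 1.3-fold lower number from compound 3 to compound 4 (0.11 log units; within the scatter). For compound 4 the estimated value is 40000 nM, within an expected range of 18000 nM to 85000 nM.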

Compound 4, half-maximal inhibitory concentration: 20000 nM
Beside the measured number, compound 4's estimate is 2.0-fold (0.30 log units) above it; the measured number falls inside the stated range.
By their numbers in this assay, from the lowest: compounds 1 and 4 (each within the scatter of the next); then compounds 3 and 2 (each within the scatter of the next).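

In this assay, among the compounds shown here, the earlier compounds changed the whole substituted phenyl on the amide nitrogen, whereas this pair shows that a single substituent, meta to a large group on the aromatic ring, can move the number beyond the scatter: chloro in place of fluoro gives a modest step (a 2.6-fold lower number from compound 3 to compound 4 (0.41 log units; beyond the scatter)). The 3-chlorophenyl compound also stands apart from the 2-methoxyphenyl compound (a 4.6-fold lower number from compound 2 to compound 4 (0.66 log units; beyond the scatter)), yet it remains together with the 4-isopropylphenyl compound (a 1.6-fold higher number from compound 1 to compound 4 (0.21 log units; within the scatter)). Nothing available explains this step.

From the compounds shown here alone, whether bromo or a methyl group at this same place would extend the step remains open. So does whether chloro elsewhere on the aromatic ring would keep it.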